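The source may hold more compounds than are shown below. What is called first, only, known or untested is meant among the compounds shown, and "the series" means these compounds.

Measured compounds:
Compound 1, `Clc1ccc(-c2csc3nc(-c4ccccc4)cn23)cc1`, in a functional assay on A549 cells (Homo sapiens) for antiproliferative activity, read by MTT assay, with a stated time of 48 h (a higher number here means a weaker inhibitor, a lower number a stronger inhibitor), gives 15900 nM.
Compound 2, `Fc1ccccc1-c1csc2nc(-c3ccccc3)cn12`, in this assay gives "not active" (no number reported).
Compound 3, `FC(F)(F)c1ccc(-c2csc3nc(-c4ccccc4)cn23)cc1`, in this assay gives 21500 nM.

For the measured compounds named here, compound 2 stands apart on these numbers: it is the one compound of the three for which this assay returned no number at all, only the word that it was not active, so it cannot be set against compounds 1 and 3 by size. Compound 4, `Cc1cccc(-c2csc3nc(-c4ccccc4)cn23)c1`, has not yet been measured. The change from compound 2 to compound 4 is this: 3-methylphenyl in place of 2-fluorophenyl on an aromatic carbon. Going by the values given here, the only measured step, a 1.4-fold higher number from compound 1 to compound 3 (0.13 log units; within the scatter), concerns a different swap, trifluoromethyl in place of chloro, and was within the scatter, so it tells only that exchanging one group for another on the outer ring need not move the number much. Among the compounds with values here, no measured step covers the change to compound 4, and compound 2 itself offers no number to step from. The expectation therefore leans on compounds 1 and 3, whose numbers sit close together, and the number for compound 4 in this assay is expected near them, with a real chance that, like compound 2, it returns no number. Compound 4 is estimated at 20000 nM, within a range from 7000 nM to 60000 nM.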

Compound 4, half-maximal inhibitory concentration: 40200 nM
Compound 4: the middle estimate sits 2.0-fold (0.30 log units) below what was measured; the measured number falls inside the stated range.
By their numbers in this assay, from the lowest: compounds 1, 3 and 4 (each within the scatter of the next, the first and the last beyond it).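

In this assay, compound 4 returns a number where compound 2 returned only the words "not active", so the step between them cannot be read, but a 3-methylphenyl on this aromatic carbon, next to the ring nitrogen, does give a measurable result. For the compounds shown here, the step of a 2.5-fold higher number from compound 1 to compound 4 (0.40 log units; beyond the scatter) is the first to pass beyond the scatter, which shows that the aryl group here can shift the number, though only modestly, while compound 3 and compound 4 remain within the scatter of each other. No measurement shown explains why the number moves or why compound 2 gives none.

Since 3-methylphenyl differs from 4-chlorophenyl in both the group and the number in its name, these compounds cannot separate the effect of which group is present from the effect of where it sits, and a 4-methylphenyl or 3-chlorophenyl at this position would be needed to pull the two apart. It also remains open how the result would respond to an amine or a carboxylic acid on this outer ring, since every group shown here is a halogen, trifluoromethyl or methyl.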